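A few compounds are considered here, and "the series" means these few. Any claim that something is new, unique, unknown or untested is made for them only; others in the source may bear on it.

The series shares one core, with an aryl group on the aromatic nitrogen of the five-membered ring: compound 1 `N#Cc1cc(-c2ccccc2)n(-c2nc3ccccc3[nH]2)c1N`, compound 2 `Nc1c(-c2nc3ccccc3[nH]2)cc(-c2ccccc2)n1-c1ccncc1`, compound 3 `Nc1c(-c2nc3ccccc3[nH]2)cc(-c2ccccc2)n1-c1cccc(Br)c1` and the unmeasured compound 4 `Nc1c(-c2nc3ccccc3[nH]2)cc(-c2ccccc2)n1-c1ccc(Cl)cc1`. In a functional assay on MCF7 cells (Homo sapiens) for cytotoxicity, read by sulforhodamine B assay, with a stated time of 48 h (a higher number here means a weaker inhibitor, a lower number a stronger inhibitor), compound 1 gives 1280 nM, compound 2 gives 705 nM and compound 3 gives 2120 nM, the highest number of the three; compound 1 sits within the scatter of compound 3, compound 2 beyond it. Within the data shown here, the only step that exchanges the group on the aromatic nitrogen is a 3.0-fold higher number from compound 2 to compound 3 (0.48 log units; beyond the scatter). Compound 4 differs from compound 3 by 4-chlorophenyl in place of 3-bromophenyl on an aromatic nitrogen. Among the measured compounds shown here, no measured step exchanges one halophenyl for another, so for compound 4 a step within the scatter in this assay is expected, a 1.2-fold lower number from compound 3 to compound 4 (0.07 log units; within the scatter). Compound 4 is expected to give 1800 nM, between 900 nM and 3600 nM.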

Compound 4, half-maximal inhibitory concentration: 934 nM
For compound 4 the middle estimate is 1.9-fold (0.28 log units) above the measured one; the range from low to high includes it.
By their numbers in this assay, from the lowest: compounds 2, 4, 1 and 3 (each within the scatter of the next, the first and the last beyond it).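

In this assay the halophenyl group on the aromatic nitrogen is not interchangeable: 4-chlorophenyl in place of 3-bromophenyl gives a 2.3-fold lower number from compound 3 to compound 4 (0.36 log units; beyond the scatter) and lies beyond the scatter. A carbon-only aryl group here can also stay within the scatter of pyridin-4-yl, as a 1.3-fold higher number from compound 2 to compound 4 (0.12 log units; within the scatter) shows, which the earlier step to 3-bromophenyl did not. No measurement given here accounts for either step.

From the compounds shown here alone, the halogen and its place on the ring change together, and how much of the step belongs to each stays open. Also open, going by these compounds, is how a phenyl group carrying an amine or a carboxylic acid would compare.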